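Halogen swap on the benzyl ring, ortho versus meta

The compounds below may be only part of what the source reports. "The series", "measured", "known", "first", "only" and "open" are said of these compounds alone.

Compound 1 `O=C1OC[C@H](Cc2ccccc2)[C@H]1Cc1ccccc1F` carries a 2-fluorophenyl group on the shared core; compound 2 `O=C1OC[C@H](Cc2ccccc2)[C@H]1Cc1ccccc1Cl` is its chloro analogue, and compound 3 `O=C1OC[C@H](Cc2ccccc2)[C@H]1Cc1cccc(F)c1` moves the fluorine to the 3-fluorophenyl arrangement. Compound 4 `O=C1OC[C@H](Cc2ccccc2)[C@H]1Cc1cccc(Cl)c1`, not yet measured, is the chloro counterpart of compound 3.

In a functional assay on HL-60 cells (Homo sapiens) for cytotoxicity, read by WST assay, with a stated time of 48 h (a higher number here means that more compound is needed for the effect, a lower number that less compound is needed), compound 1 gives 72000 nM, compound 2 gives 37000 nM and compound 3 gives 75000 nM. The change chloro in place of fluoro on an aromatic carbon produced a 1.9-fold lower number from compound 1 to compound 2 (0.29 log units; within the scatter). The core difference 3-fluorophenyl in place of 2-fluorophenyl on a saturated chain carbon bound to a saturated ring carbon gave a 1.0-fold higher number from compound 1 to compound 3 (0.02 log units; within the scatter), so compound 1 and compound 3 cannot be told apart here. Between compound 2 and compound 3 the step is a 2.0-fold higher number from compound 2 to compound 3 (0.31 log units; beyond the scatter).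

Among the measured compounds shown here, the change chloro in place of fluoro on an aromatic carbon is the same kind of change as the one from compound 1 to compound 2, not the same: there the halogen sits ortho to a large group, here meta to a large group. For the measured compounds named here, the only measured precedent is the step from compound 1 to compound 2, which lies within the scatter, so the expectation for compound 4 is weak. A step of about a 1.9-fold lower number from compound 3 to compound 4 (0.27 log units; within the scatter) is expected for compound 4 in this assay, resting on compound 3 at 75000 nM and on the earlier step of a 1.9-fold lower number from compound 1 to compound 2 (0.29 log units; within the scatter). Compound 4 is therefore estimated at 40000 nM in this assay, with the range 20000 nM to 85000 nM.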

Compound 4, half-maximal effective concentration: 36000 nM
Beside the measured number, compound 4's estimate is 1.1-fold (0.05 log units) above it; measured number inside the range.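

Chloro in place of fluoro gives a 2.1-fold lower number from compound 3 to compound 4 (0.32 log units; beyond the scatter) in this assay, and this step agrees with the earlier one on the 2-fluorophenyl compound: the same change on two cores in this assay, a 1.9-fold lower number (0.29 log units; within the scatter) from compound 1 to compound 2 and a 2.1-fold lower number (0.32 log units; beyond the scatter) from compound 3 to compound 4, 1.1-fold (0.03 log units) apart, within the scatter of two such steps. Among the chloro compounds, the move to 3-chlorophenyl gives a 1.0-fold lower number from compound 2 to compound 4 (0.01 log units; within the scatter), so the two cannot be told apart, while the pair that differs in both halogen and placement shows a 2.0-fold lower number from compound 1 to compound 4 (0.30 log units; within the scatter); across these four compounds, the number follows the halogen more closely than its placement. This shows the change carrying over only between two closely related arrangements on the shared core and in this single cell assay, with one step within the scatter and the other only just beyond it, so it does not show that the change would carry over to a different core or to another read-out.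

The compounds shown leave open whether the same step holds for bromo or methyl on this ring, or for the halogen on the other phenyl ring. They also leave open whether a group of another kind, such as an amine or a carboxylic acid, would move the number further than either halogen does.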